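A few compounds are considered here, and "the series" means these few. Any claim that something is new, unique, unknown or untested is made for them only; others in the source may bear on it.

In a functional assay on DU-145 cells (Homo sapiens) for cytotoxicity, read by trypan blue exclusion, with a stated time of 96 h (a higher number here means a weaker inhibitor, a lower number a stronger inhibitor), compound 1 (`COc1ccc(NS(=O)(=O)/C=C/c2c(OC)cc(OC)cc2OC)cc1`) gives 200 nM and compound 2 (`COc1cc(OC)c(/C=C/S(=O)(=O)Nc2ccc(OC)c([N+](=O)[O-])c2)c(OC)c1`) gives 2500 nM while compound 3 (`COC(=O)C(Nc1cc(NS(=O)(=O)/C=C/c2c(OC)cc(OC)cc2OC)ccc1OC)c1ccccc1`) gives 2500 nM in the same test. Compound 3 thus stands level with compound 2, and together they hold the highest of the three numbers. Compound 4 (`COc1cc(OC)c(/C=C/S(=O)(=O)Nc2ccc(OC)c(NCC(=O)O)c2)c(OC)c1`) is still unmeasured, and it departs from compound 3 by one change on a nitrogen on an aromatic ring (carboxymethyl in place of methoxycarbonyl)(benzyl on a nitrogen on an aromatic ring).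

Two measured steps show large losses when a group replaces a hydrogen of compound 1 (a 13-fold higher number from compound 1 to compound 2 (1.10 log units; beyond the scatter) and a 13-fold higher number from compound 1 to compound 3 (1.10 log units; beyond the scatter)). The third step bears most directly, since swapping one such group for a far larger one moved nothing (no change at the digits printed from compound 2 to compound 3 (within the scatter)). Compound 4 also carries such a group, so it resembles compound 2 and compound 3 more than compound 1. Going by the values given here, no measured compound carries carboxymethyl, however, so this remains uncertain. In this assay no change beyond the scatter is expected, and the estimated step is (a 1.2-fold higher number from compound 3 to compound 4 (0.08 log units; within the scatter)) at most modest. For compound 4 the estimate is 3000 nM with an expected range from 600 nM to 15000 nM overall.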

Compound 4, half-maximal inhibitory concentration: 400 nM
Estimate against measurement, compound 4: 7.5-fold (0.88 log units) above, outside the stated range (below it).
By their numbers in this assay, from the lowest: compounds 1 and 4 (each within the scatter of the next); then compounds 2 and 3 (each within the scatter of the next).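

In this assay the two groups seen earlier on this aromatic carbon both cost the same large amount, so any replacement of the hydrogen there might have seemed harmful. (Carboxymethyl)amino breaks that picture: it sits within the scatter of the unsubstituted parent (a 2.0-fold higher number from compound 1 to compound 4 (0.30 log units; within the scatter)), and it beats nitro at the same place (a 6.3-fold lower number from compound 2 to compound 4 (0.80 log units; beyond the scatter)). Exchanging the far larger group on the nitrogen for carboxymethyl also gains ground (a 6.3-fold lower number from compound 3 to compound 4 (0.80 log units; beyond the scatter)), so the outcome depends on which group stands here, not merely on whether one does.

The compounds shown do not separate the part played by the amine nitrogen from that of the carboxylic acid. A plain amino group, the methyl ester of the carboxymethyl group or a longer chain ending in a carboxylic acid would test this. Nothing measured here accounts for the differences between these groups.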